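From 3-azido-4-methoxybenzyl to 3-hydroxy-4-methoxybenzyl

The source may hold more compounds than are shown below. What is called first, only, known or untested is meant among the compounds shown, and "the series" means these compounds.

Measured in a functional assay on HCT-116 cells (Homo sapiens) for inhibition, read by CCK-8 assay, with a stated time of 48 h; a lower number here means a stronger inhibitor, a higher number a weaker inhibitor:
- compound 1 `COc1ccc(CN(C(=O)CSC(=S)N2CCN(C(=O)OC(C)(C)C)CC2)c2cc(OC)c(OC)c(OC)c2)cc1` gives 620 nM
- compound 2 `COc1ccc(CN(C(=O)CSC(=S)N2CCN(C(=O)OC(C)(C)C)CC2)c2cc(OC)c(OC)c(OC)c2)cc1Br` gives 9710 nM
- compound 3 `COc1ccc(CN(C(=O)CSC(=S)N2CCN(C(=O)OC(C)(C)C)CC2)c2cc(OC)c(OC)c(OC)c2)cc1N=[N+]=[N-]` gives 780 nM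

Compound 3 sits level with compound 1, with a 1.3-fold higher number from compound 1 to compound 3 (0.10 log units; within the scatter). It is far from compound 2, with a 12-fold lower number from compound 2 to compound 3 (1.10 log units; beyond the scatter). The next change leads to compound 4 `COc1ccc(CN(C(=O)CSC(=S)N2CCN(C(=O)OC(C)(C)C)CC2)c2cc(OC)c(OC)c(OC)c2)cc1O`, with hydroxy in place of azido on an aromatic carbon.

Among the measured compounds shown here, no hydroxy compound has been measured in this set, so only the steps at this same carbon bear on the change. Azido in place of hydrogen gave a 1.3-fold higher number from compound 1 to compound 3 (0.10 log units; within the scatter), whereas bromo in place of hydrogen gave a 16-fold higher number from compound 1 to compound 2 (1.19 log units; beyond the scatter). These three compounds show that a change here can leave the number in place or shift it a long way.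

No step beyond the scatter is expected in this assay, and no direction is favoured. The expected step is a 1.6-fold lower number from compound 3 to compound 4 (0.19 log units; within the scatter). The upper end stays wide because of a 16-fold higher number from compound 1 to compound 2 (1.19 log units; beyond the scatter). For compound 4 the estimated value is 500 nM, with an expected range of 120 nM to 2500 nM.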

Compound 4, half-maximal inhibitory concentration: 128 nM
For compound 4 the middle estimate is 3.9-fold (0.59 log units) above the measured one; the range from low to high includes it.
By their numbers in this assay, from the lowest: compound 4; then compounds 1 and 3 (each within the scatter of the next); then compound 2.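

In this assay, among the compounds shown here, the step of a 4.8-fold lower number from compound 1 to compound 4 (0.69 log units; beyond the scatter) shows that a group at this carbon can also lower the number relative to hydrogen, whereas azido and bromo had so far left it in place or raised it. The step of a 6.1-fold lower number from compound 3 to compound 4 (0.78 log units; beyond the scatter) shows that azido and hydroxy are not interchangeable here, even though azido in place of hydrogen stayed within the scatter, and the step of a 76-fold lower number from compound 2 to compound 4 (1.88 log units; beyond the scatter) is the widest gap yet seen among groups on this carbon. Nothing available explains why hydroxy stands apart from azido and bromo.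

The compounds shown leave open whether an amine, a methoxy or a carboxylic acid on this carbon would track hydroxy or bromo. They also leave open whether the gain from hydroxy in place of hydrogen carries over to another core.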